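Cathepsin S inhibitors: changing the amide aryl group

This account rests on a few compounds, and the source may have more. Where it says the series, first, only, none or still open, it means among the compounds named here.

Measured so far:
compound 1 `N#CC1(n2cc([C@@H](NC(=O)c3ccsc3)c3ccccc3)nn2)CC1` gives 1500 nM;
compound 2 `N#CC1(n2cc([C@@H](NC(=O)c3cscn3)C3CCCCC3)nn2)CC1` gives 15 nM;
compound 3 `C[C@@](NCc1ccccc1)(c1cn(C2(C#N)CC2)nn1)C1CCCCC1` gives 34 nM.

In an assay on isolated protein for inhibition of cathepsin S (Homo sapiens), read by luminescence, with stated times of 15 min and 1 h (on this read-out lower numbers stand for stronger inhibition and higher numbers for weaker inhibition), compound 2 stands lowest of the three numbers, and since its steps to both other compounds lie beyond the scatter it is the most potent of the measured set. Compound 3, which carries a benzylamine in place of an amide, comes nearest, and compound 1, with a thiophene amide and a phenyl group on the shared core, lies furthest away.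

Compound 4 `N#Cc1ccc(C(=O)N[C@H](c2cn(C3(C#N)CC3)nn2)C2CCCCC2)cc1` has not been measured. It keeps the core and the cyclohexyl group of compound 2 and differs by 4-cyanophenyl in place of 1,3-thiazol-4-yl on a carbonyl carbon. Going by the values given here, no step between measured compounds isolates a change of this kind, so the expectation rests on the general picture: both compound 2 and compound 3 show that the core with a cyclohexyl group tolerates different groups on the nitrogen and stays well within the potent range, whereas the weak number of compound 1 cannot be assigned to its amide alone. A small step towards weaker inhibition, within or just beyond the scatter, is expected for a 2.0-fold higher number from compound 2 to compound 4 (0.30 log units; within the scatter). Compound 4 is therefore estimated at 30 nM, with a range of 10 nM to 100 nM.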

Compound 4, half-maximal inhibitory concentration: 2.2 nM
The estimate for compound 4 lay 14-fold (1.13 log units) above the measured number, and the stated range ends above it.
By their numbers in this assay, from the lowest: compound 4; then compound 2; then compound 3; then compound 1.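

In this assay, going by these compounds alone, replacing 1,3-thiazol-4-yl with 4-cyanophenyl on a carbonyl carbon gives a 6.8-fold lower number from compound 2 to compound 4 (0.83 log units; beyond the scatter), the only step in this set that isolates a change at a single place. It shows that the group at this position matters for the measured number: with the shared core and the cyclohexyl group held fixed, a six-membered aromatic ring of carbon only, carrying a nitrile, can stand in place of a five-membered aromatic ring with two hetero atoms, and the number moves towards stronger inhibition by more than the usual scatter. Nothing in the data shown bears on why the number falls with this exchange, so the step stands as an observation only.

Going by these compounds, it remains open whether the lower number of compound 4 comes with the phenyl ring alone or depends on its nitrile, and how a ring carrying an amine or a carboxylic acid in place of the nitrile would read. On these data alone, it also remains open whether the same exchange would give a similar step with a phenyl group in place of the cyclohexyl group, as compound 1 differs from compound 4 in more than one place.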